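The source may report more compounds than this note shows. Statements on the series, on what has been measured and on what is new or still open speak of the compounds shown alone.

Measured compounds in an assay on HeLa cells for inhibition of sphingosine-1-phosphate transporter SPNS2 (Mus musculus), read by LC-MS, tested at 2 uM; a lower number here means less inhibition, a higher number more inhibition at the concentration tested (going by the name of the read-out):
compound 1, `CCCCCCCCCCc1ccc(-c2noc(C3CNC3)n2)cc1`: 65%
compound 2, `CCCCCCCCCCc1ccc(-c2noc(CCCN(C)C)n2)cc1`: 8%
compound 3, `CCCCCCCCCCc1ccc(-c2noc([C@@H]3CCCN3)n2)cc1`: 21%

Compound 3 stands second highest of the three values in this assay: compound 2 lies nearest, a number 13 percentage points higher from compound 2 to compound 3 (beyond the scatter), while compound 1 lies furthest, a number 44 percentage points lower from compound 1 to compound 3 (beyond the scatter). Compound 4, `CCCCCCCCCCc1ccc(-c2noc([C@@H]3CCC[C@@H](N)C3)n2)cc1`, has not yet been measured. It differs from compound 3 in one place, (3-aminocyclohexyl in place of pyrrolidin-2-yl on an aromatic carbon), the group sitting on an aromatic carbon of the shared core.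

Among the measured compounds shown here, two measured steps bear on this change, both of them exchanges of the amine-bearing group on that same aromatic carbon. The exchange of azetidin-3-yl for pyrrolidin-2-yl gave a number 44 percentage points lower from compound 1 to compound 3 (beyond the scatter), and the exchange of 3-(dimethylamino)propyl for pyrrolidin-2-yl gave a number 13 percentage points higher from compound 2 to compound 3 (beyond the scatter). Together they show that this position moves the read-out strongly in either direction, and that the small ring of compound 1 has so far given the highest number, with compound 3 and compound 2 below it. Compound 4 carries a ring again, though a larger one of carbon only with a free amine; the step of a number 19 percentage points higher from compound 3 to compound 4 (beyond the scatter) is therefore expected to be upward but moderate, and compound 4 is estimated at 40%, between 10% and 75%.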

Compound 4, a percentage reported as inhibition, at one concentration (the size of the read-out at that concentration, not a potency): 13%
For compound 4 the middle estimate is 27 percentage points above the measured one, within the range that was stated.
By their numbers in this assay, from the lowest: compounds 2, 4 and 3 (each within the scatter of the next, the first and the last beyond it); then compound 1.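

In this assay, the exchange of pyrrolidin-2-yl for 3-aminocyclohexyl gave a number 8 percentage points lower from compound 3 to compound 4 (within the scatter), and the exchange of 3-(dimethylamino)propyl for 3-aminocyclohexyl gave a number 5 percentage points higher from compound 2 to compound 4 (within the scatter), so these three groups cannot be told apart on this read-out, although the third group differs from the other two in its ring and its number of stereocentres. The exchange of azetidin-3-yl for 3-aminocyclohexyl gave a number 52 percentage points lower from compound 1 to compound 4 (beyond the scatter), which shows that a non-aromatic ring bearing an amine at this position is not enough to reach the number of compound 1, and that among the four compounds only azetidin-3-yl stands apart. No measurement available here accounts for this separation.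

The compounds shown leave open whether the number of compound 1 depends on the small four-membered ring or on having the nitrogen within the ring, a question that 3-aminocyclobutyl, with its amine outside a small ring, and piperidin-4-yl, with its nitrogen inside a larger ring, would address. They also leave open how the other stereoisomers of 3-aminocyclohexyl would read in this assay.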